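From compound 3 to compound 4: a larger amide group

This account rests on a few compounds, and the source may have more. Where it says the series, first, only, none or still open, it means among the compounds named here.

Measured in a functional assay on NCI-H1975 cells (Homo sapiens) for antiproliferative activity, read by CCK-8 assay, with a stated time of 72 h; a lower number here means a stronger inhibitor of growth, a higher number a weaker inhibitor of growth:
compound 1 `CCC1C(=O)N(C)c2cnc(-n3ccc4cc(C(=O)NC(C)C)ccc43)nc2N1c1ccn(C)n1` gives 12200 nM
compound 2 `CCC1C(=O)N(C)c2cnc(-n3ccc4cc(F)ccc43)nc2N1c1ccn(C)n1` gives 28600 nM
compound 3 `CCNC(=O)c1ccc2c(ccn2-c2ncc3c(n2)N(c2ccn(C)n2)C(CC)C(=O)N3C)c1` gives "not active" (no number reported)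

Going by the values given here, compound 3 stands without a number, so no step can be counted from it. Compound 4 `CCC1C(=O)N(C)c2cnc(-n3ccc4cc(C(=O)NCC(C)C)ccc43)nc2N1c1ccn(C)n1` carries isobutylcarbamoyl in place of ethylcarbamoyl (isopropyl in place of methyl on a saturated chain carbon bound to an amide-type nitrogen). Among the compounds with values here, the only measured step, a 2.3-fold higher number from compound 1 to compound 2 (0.37 log units; beyond the scatter) as it stands, is modest and replaces the whole amide group with fluoro, so it bears only loosely on this change. Compound 1, with isopropylcarbamoyl, at 12200 nM is the closest guide. No step size from compound 3 can be expected, and a result without a number remains possible. In this assay compound 4 is estimated at 15000 nM with an expected range from 5000 nM to 40000 nM overall.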

Compound 4, concentration for 50% growth inhibition: 10200 nM
The estimate for compound 4 lay 1.5-fold (0.17 log units) above the measured number, and the stated range covers the measured number.
By their numbers in this assay, from the lowest: compounds 4 and 1 (each within the scatter of the next); then compound 2.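

In this assay, compound 4 carries a number while compound 3, with ethylcarbamoyl, is reported as not active, so the change from ethyl to isobutyl cannot be read as a step. Changing isopropyl to isobutyl on the amide-type nitrogen gives a 1.2-fold lower number from compound 1 to compound 4 (0.08 log units; within the scatter), and isobutylcarbamoyl in place of fluoro on an aromatic carbon gives a 2.8-fold lower number from compound 2 to compound 4 (0.45 log units; beyond the scatter). No evidence accompanies these results to explain them. The compounds shown leave open whether a longer chain or an amine on the amide-type nitrogen would lower the number further.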